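From methoxy to chloro on compound 3

A few compounds are considered here, and "the series" means these few. Any claim that something is new, unique, unknown or untested is made for them only; others in the source may bear on it.

Measured so far in an ADME assay on HEK293 cells (Homo sapiens) for cytotoxicity, read by fluorescence and resazurin assay, with a stated time of 24 h; a lower number here means that less compound is tolerated, a higher number that more compound is tolerated:
compound 1 `O=S1(=O)C=C(Sc2nnc(C3CCCCC3)o2)c2ccccc21` gives 3000 nM
compound 2 `O=S1(=O)C=C(Sc2nnc(-c3ccccc3Cl)o2)c2ccccc21` gives 4000 nM
compound 3 `COc1cccc(-c2nnc(SC3=CS(=O)(=O)c4ccccc43)o2)c1` gives 3000 nM

Compound 3 stands at 3000 nM level with compound 1 and within the scatter of compound 2. Compound 4 `O=S1(=O)C=C(Sc2nnc(-c3cccc(Cl)c3)o2)c2ccccc21` carries chloro in place of methoxy on an aromatic carbon and so turns 3-methoxyphenyl into 3-chlorophenyl. Within the data shown here, no measured step makes this exact exchange. The nearest evidence is the three swaps of this group on the shared core: a 1.3-fold lower number from compound 2 to compound 3 (0.12 log units; within the scatter) together with no change at the digits printed from compound 1 to compound 3 (within the scatter) and a 1.3-fold higher number from compound 1 to compound 2 (0.12 log units; within the scatter) all stay within the scatter. In this assay the expected change is therefore none beyond the scatter, with an estimated 1.2-fold higher number from compound 3 to compound 4 (0.07 log units; within the scatter) as the likely step. Compound 4 is estimated at 3500 nM (1800 nM to 7000 nM).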

Compound 4, half-maximal cytotoxic concentration: 6000 nM
Beside the measured number, compound 4's estimate is 1.7-fold (0.23 log units) below it; low and high end bracket the measured number.
By their numbers in this assay, from the lowest: compounds 1, 3, 2 and 4 (each within the scatter of the next).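

In this assay the exchange of chloro for methoxy gives a 2.0-fold higher number from compound 3 to compound 4 (0.30 log units; within the scatter), and the other two swaps give a 1.5-fold higher number from compound 2 to compound 4 (0.18 log units; within the scatter) and a 2.0-fold higher number from compound 1 to compound 4 (0.30 log units; within the scatter). A fourth group at this position thus adds no step beyond the scatter, and 2-chlorophenyl and 3-chlorophenyl cannot be told apart here. No evidence at hand accounts for these numbers.

The compounds shown leave open whether an amine or a carboxylic acid on this aromatic ring, or a longer chain in its place, would give a step beyond the scatter.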